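Shorter Chain, Expected Lower Lipophilicity: Compound 3 to Compound 4

The compounds below may be only part of what the source reports. "The series", "measured", "known", "first", "only" and "open" are said of these compounds alone.

Measured so far:
compound 1 `CC(C)N(C)/N=N/c1ccc(C(=O)O)cc1` — 0.34
compound 2 `CCCCCCN(C)/N=N/c1ccc(C(=O)O)cc1` — 1.95
compound 3 `CCCCCCCCN(C)/N=N/c1ccc(C(=O)O)cc1` — 2.77

These three compounds share one core and differ only in the alkyl group on the amine nitrogen. In a physicochemical assay for lipophilicity, in phosphate buffer, measured as octanol-water partition, at pH 7.4 (on this read-out lower numbers stand for lower lipophilicity and higher numbers for higher lipophilicity), compound 3 gives the highest of the three values; the nearest is compound 2, and compound 1 lies furthest below. The step of a number 1.61 log units higher from compound 1 to compound 2 (beyond the scatter) is large, and the step of a number 0.82 log units higher from compound 2 to compound 3 (beyond the scatter) is modest, so longer chains have gone together with higher numbers across all three compounds.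

Compound 4 `CCCCN(C)/N=N/c1ccc(C(=O)O)cc1` has not yet been measured. The change from compound 3 is hydrogen in place of butyl on a saturated chain carbon, four bonds along the chain from an amine nitrogen. It reverses the direction of the two measured steps: where those added chain carbons and raised the number, this one removes chain carbons. Both steps bear on it, since each added chain length on the same nitrogen; the modest rise for two added carbons and the large rise for the earlier change suggest that removing four carbons should lower the number clearly beyond the scatter.

Compound 4 is therefore expected to give a step of a number 1.62 log units lower from compound 3 to compound 4 (beyond the scatter), an estimate of 1.15 with a range from 0.75 to 1.55.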

Compound 4, distribution coefficient: 0.97
Compound 4: the middle estimate sits 0.18 log units above what was measured, and the stated range covers the measured number.
By their numbers in this assay, from the lowest: compound 1; then compound 4; then compound 2; then compound 3.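

In this assay, within the data shown here, the change from butyl to hydrogen at this place, four bonds along the chain from an amine nitrogen, gives the step of a number 1.80 log units lower from compound 3 to compound 4 (beyond the scatter) and shows that shortening the chain lowers the number, whereas the earlier steps showed only chain lengthening raising it. Compared with the hexyl compound, the same place gives the step of a number 0.98 log units lower from compound 2 to compound 4 (beyond the scatter) and thus places compound 4 on the low side of compound 2, while the step of a number 0.63 log units higher from compound 1 to compound 4 (beyond the scatter) shows that butyl still stands clear of isopropyl on the amine nitrogen, so that across all four compounds longer chains go with higher numbers and none goes against this. Nothing available here bears on the cause of these steps.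

Among these compounds, a longer chain than the one in compound 3 could continue this rise or level off, and a branched butyl group such as tert-butyl would help separate chain length from branching, since isopropyl and butyl differ in both. On these data alone, how a chain ending in a hydroxyl group or an amine would compare with these plain alkyl chains also remains open.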